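This account rests on a few compounds, and the source may have more. Where it says the series, first, only, none or still open, it means among the compounds named here.

Compound 1 `NCCCCCCC(=O)Nc1nc2ccc(C(=O)c3ccccc3)cc2[nH]1`: > 30000 nM
Compound 2 `CN1CCC(Cn2c(N)nc3ccc(C(=O)c4ccccc4)cc32)CC1`: > 30000 nM

In an ADME assay on HL-60 cells (Homo sapiens) for cytotoxicity, read by resazurin assay, with a stated time of 72 h (a lower number here means that less compound is needed, a higher number that more compound is needed for the effect), compound 1 gives > 30000 nM, which is a limit of the assay rather than a number. Compound 2 likewise gives > 30000 nM in this assay, again only a limit. For the measured compounds named here, compound 2 therefore stands at the limit of > 30000 nM in this assay, at which 2 of the 2 values shown sit; no measured step separates it from compound 1, and nothing beyond what the two limits show can be said of the pair.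

Compound 3 `CN1CCC[C@@H]1Cn1c(N)nc2ccc(C(=O)c3ccccc3)cc21` has not yet been measured in this assay. It differs from compound 2 in one place: 1-methylpyrrolidin-2-yl in place of 1-methylpiperidin-4-yl on a saturated chain carbon bound to an aromatic nitrogen. Going by the values given here, no measured step offers a guide to the size of this change. A step of no more than the usual scatter is expected, a step that the limit leaves unreadable from compound 2 to compound 3. Compound 3 is accordingly estimated at 40000 nM, within a range from 12000 nM to 120000 nM, with a strong chance that only a limit is reported once more.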

Compound 3, half-maximal effective concentration: > 30000 nM
Compound 3: only a limit was reported; the forecaster's own chance of this, stated with the estimate: 70%; the middle value is on the limit's open side.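

In this assay, compound 2 and compound 3 both give only a limit, so no step can be read between them: the limit of > 30000 nM in this assay, at which 3 of the 3 values shown sit.

The compounds shown leave open whether 1-methylpyrrolidin-2-yl and 1-methylpiperidin-4-yl differ at all in this assay, and which change to the shared core would give a measurable value.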